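Trimming One Ethyl Group to Methyl on Compound 1

The source may hold more compounds than are shown below. What is called first, only, known or untested is meant among the compounds shown, and "the series" means these compounds.

In a functional assay on KBVIN cells (Homo sapiens) for cytotoxicity, read by sulforhodamine B assay, with a stated time of 3 days (on this read-out higher numbers stand for an effect only at larger amounts of compound and lower numbers for an effect already at smaller amounts), compound 1 `CCC1=C(O)c2c(oc(-c3ccc(CC)cc3)cc2=O)C(CC)(CC)C1=O` gives 0.025 ug/mL and so holds the lower of the two numbers available. Going by the values given here, the only other compound measured, compound 2 `CCCC1=C(OC)C(CCC)(CCC)C(=O)/C(=C(O)\C=C\c2ccc(Br)cc2)C1=O` gives 0.9 ug/mL and that gap lies beyond the usual scatter of repeated measurements. Among the compounds with values here, no two measured compounds differ in just one place, so no measured step can guide the next change.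

Compound 3 `CCC1=C(O)c2c(oc(-c3ccc(C)cc3)cc2=O)C(CC)(CC)C1=O` keeps the core of compound 1 and alters a single group: 4-ethylphenyl becomes 4-methylphenyl, which means hydrogen in place of methyl on a saturated chain carbon bound to an aromatic carbon. This is a small edit, so the expectation starts from compound 1 at 0.025 ug/mL and stays close to it. The expected step of a 1.6-fold higher number from compound 1 to compound 3 (0.20 log units; within the scatter) is toward a slightly higher number, but not beyond the scatter. In this assay the estimate for compound 3 is 0.04 ug/mL with an expected range from 0.012 ug/mL to 0.15 ug/mL in all.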

Compound 3, half-maximal effective concentration: 0.03 ug/mL
The estimate for compound 3 lay 1.3-fold (0.12 log units) above the measured number; low and high end bracket the measured number.
By their numbers in this assay, from the lowest: compounds 1 and 3 (each within the scatter of the next); then compound 2.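

Going by these compounds alone, replacing 4-ethylphenyl with 4-methylphenyl is the first change here that can be read on its own. Only one place differs. In this assay the change gives a 1.2-fold higher number from compound 1 to compound 3 (0.08 log units; within the scatter) and nothing more. This shows that one carbon can leave this saturated chain, at the carbon bound to an aromatic carbon, without the number moving outside what repeated measurements of the same compound would give. Compound 1 and compound 3 therefore count as equal on this read-out and cannot be ranked, which the earlier comparison with compound 2 could not show, since that compound differs in many places at once. Nothing measured here explains why the number holds, so the result stands as an observation only.

From the compounds shown here alone, the step covers only the trim from ethyl to methyl, so it remains open how far this tolerance reaches, for example with a longer chain such as butyl or with a very different group such as an amine or a carboxylic acid in the same place. Going by these compounds, whether the rest of the shared core would accept a similarly small edit as readily is also open.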